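Acrylamide triazine series: antiproliferative read-out, swap at the para position

The compounds below may be only part of what the source reports. "The series", "measured", "known", "first", "only" and "open" are said of these compounds alone.

Compound 2, `C=CC(=O)Nc1cccc(Nc2ncnc(Nc3ccc(-c4ccc(C)nc4)cc3)n2)c1`, gives 13800 nM in a functional assay on Raji cells (Homo sapiens) for antiproliferative activity, read by CCK-8 assay, with a stated time of 24 h; on this read-out lower numbers stand for stronger inhibition and higher numbers for weaker inhibition. Among the three measured compounds it holds the second highest number: compound 1, `C=CC(=O)Nc1cccc(Nc2nc(N)nc(Nc3ccc(OCCOC)cc3)n2)c1`, gives 18300 nM and sits within the scatter of compound 2, while compound 3, `C=CC(=O)N1CCc2ccc(Nc3ncnc(Nc4ccc(C(=O)N5CCCCC5)cc4)n3)cc21`, gives 2840 nM, a number lying beyond the scatter below compound 2.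

Compound 4, `C=CC(=O)Nc1cccc(Nc2ncnc(Nc3ccc(C(=O)N4CCCCC4)cc3)n2)c1`, has not been measured. It differs from compound 2 by (piperidin-1-yl)carbonyl in place of 6-methylpyridin-3-yl on an aromatic carbon; the rest of the molecule is unchanged. For the measured compounds named here, no single-change step between two measured compounds is available to size this exchange. Going by the values given here, what can be said is that compound 3, the only measured compound that carries the (piperidin-1-yl)carbonyl group, shows the lowest number of the three, although compound 3 also differs from compound 4 elsewhere, so its value is only a loose pointer.

The step from compound 2 to compound 4 is therefore expected to fall toward a lower number in this assay, by about a 2.3-fold lower number from compound 2 to compound 4 (0.36 log units; beyond the scatter), though it may not exceed the scatter. Compound 4 is estimated at 6000 nM, within a range of 2000 nM to 18000 nM.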

Compound 4, half-maximal inhibitory concentration: 5140 nM
Estimate against measurement, compound 4: 1.2-fold (0.07 log units) above, and the stated range covers the measured number.
By their numbers in this assay, from the lowest: compounds 3 and 4 (each within the scatter of the next); then compounds 2 and 1 (each within the scatter of the next).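

In this assay, for the compounds shown here, the exchange of 6-methylpyridin-3-yl for (piperidin-1-yl)carbonyl on an aromatic carbon gives a 2.7-fold lower number from compound 2 to compound 4 (0.43 log units; beyond the scatter) and supplies the first single-change step. This modest step shows that the group at this place alone shifts the read-out beyond the scatter while the rest of the molecule stays unchanged. No measured property or other supporting data accounts for the step.

A single pair cannot show whether the carbonyl or the piperidine ring carries the shift, and a morpholine amide or a piperidin-1-yl group joined directly to the aromatic ring at this place would help separate the two. From the compounds shown here alone, whether the same step holds on the core of compound 1 also remains open.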